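This account rests on a few compounds, and the source may have more. Where it says the series, first, only, none or still open, it means among the compounds named here.

Working notes on the series.

Compound 1 `O=C(Nc1cccc(-n2cc(-c3ccncc3)c(-c3cc(O)cc(Cl)c3)n2)c1)Nc1ccc(Cl)c(Cl)c1` is the hydroxy member of this set. In a functional assay on UACC-62 cells (Homo sapiens) for inhibition, read by sulforhodamine B assay, with a stated time of 48 h, tested at 1 uM (a higher number here means a weaker effect of the compound at the concentration tested, a lower number a stronger effect), compound 1 gives 83%, the highest of the three numbers recorded. Compound 2 `COc1cc(Cl)cc(-c2nn(-c3cccc(NC(=O)Nc4ccc(Cl)c(C(F)(F)F)c4)c3)cc2-c2ccncc2)c1` sits within the scatter of that figure: in this assay compound 2 gives 82%, so no order can be read between the two. Compound 3 `COc1cc(Cl)cc(-c2nn(-c3cccc(NC(=O)Nc4cc(C(F)(F)F)cc(C(F)(F)F)c4)c3)cc2-c2ccncc2)c1` stands apart, beyond the scatter: in this assay compound 3 gives 18%. Nothing else in the set is recorded as a single-point step between measured compounds, so how much the urea aryl or the phenol matters on its own is not established by the numbers themselves.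

Compound 4 `COc1cc(Cl)cc(-c2nn(-c3cccc(NC(=O)Nc4ccc(Cl)c(Cl)c4)c3)cc2-c2ccncc2)c1` has not been measured. Against compound 1 the change is methyl in place of hydrogen on an oxygen on an aromatic ring. The resulting 3-chloro-5-methoxyphenyl is the group carried by compound 2 and compound 3, whose numbers fall on both sides, so the group by itself settles little. Among the measured compounds shown here, with no measured step of this kind to lean on, the expected step in this assay from compound 1 to compound 4 is a number 5 percentage points lower from compound 1 to compound 4 (within the scatter), small and within the scatter. Compound 4 is therefore estimated at 78% in this assay, with a range from 55% to 95%.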

Compound 4, a percentage reported as activity, at one concentration (the size of the read-out at that concentration, not a potency): 75%
Beside the measured number, compound 4's estimate is 3 percentage points above it; the range from low to high includes it.
By their numbers in this assay, from the lowest: compound 3; then compounds 4, 2 and 1 (each within the scatter of the next).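

In this assay, among the compounds shown here, the first readable step at this position, hydroxy to methoxy on the aryl group, gives a number 8 percentage points lower from compound 1 to compound 4 (within the scatter), so putting methyl on this oxygen in place of hydrogen produces no change that can be told from the scatter when the rest of compound 1 is held fixed. The second readable step, chloro in place of trifluoromethyl on an aromatic carbon of the urea aryl with the 3-chloro-5-methoxyphenyl held fixed, gives a number 7 percentage points lower from compound 2 to compound 4 (within the scatter), so this swap also stays unresolved and the two steps cannot be ranked against each other. No measurement among the data bears on the reasons behind either step.

For the compounds shown here, compound 3, at 18%, stays joined to the other compounds by no single-place step, so which feature of its urea aryl goes with its separate position cannot be read from these numbers. Also open, going by these compounds, is whether an ethyl group on the same oxygen, or an amine or a carboxylic acid in place of the hydroxy, would remain within the scatter of compound 1.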